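The compounds below may be only part of what the source reports. "The series", "measured", "known", "first", "only" and "open" are said of these compounds alone.

Compound 1 `Cn1ccc2c(-c3ccccc3)nc(NNC(=O)Nc3cc(Cl)nc(Cl)c3)nc21` gives 683000 nM in an ADME assay on NCM460 cells (Homo sapiens) for cytotoxicity, read by MTT assay, with a stated time of 72 h, in the presence of a further agent that is not named here; on this read-out lower numbers stand for an effect already at smaller amounts and higher numbers for an effect only at larger amounts of compound.
Compound 2 `O=C(Nc1cc(Cl)nc(Cl)c1)Nc1cc2ccc(Br)cn2n1` gives 8940 nM in this assay.
Compound 3 `O=C(Nc1cc(Cl)cc(Cl)c1)Nc1cc(Cl)nc(Cl)c1` gives 55400 nM in this assay.

Among these three numbers compound 3 stands second highest. Its nearest neighbour is compound 2, whose number lies below that of compound 3 by a gap beyond the usual scatter; furthest off is compound 1, whose number lies above that of compound 3, again beyond the scatter. The three measured compounds thus spread over a wide range, but each differs from the others in more than one place, so none of these gaps can be tied to a single change.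

Compound 4 `COc1c(Cl)cc(NC(=O)Nc2cc(Cl)nc(Cl)c2)cc1Cl` has not yet been measured in this assay. It differs from compound 3 in one place: methoxy in place of hydrogen on an aromatic carbon. Among the measured compounds shown here, no pair of measured compounds differs by exactly this change, so there is no step to lean on. In the absence of such a step, the change is expected to move the number little, with no shift beyond the scatter in either direction. The number for compound 4 is therefore expected near that of compound 3, estimated at 50000 nM within 15000 nM to 200000 nM. That amounts to an expected step of a 1.1-fold lower number from compound 3 to compound 4 (0.04 log units; within the scatter).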

Compound 4, half-maximal effective concentration: 27300 nM
Beside the measured number, compound 4's estimate is 1.8-fold (0.26 log units) above it; the measured number falls inside the stated range.
By their numbers in this assay, from the lowest: compound 2; then compound 4; then compound 3; then compound 1.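

In this assay, among the compounds shown here, methoxy in place of hydrogen on an aromatic carbon, ortho to two chloro groups and para to a large group, gives a 2.0-fold lower number from compound 3 to compound 4 (0.31 log units; beyond the scatter) in a modest shift, and this is the first step here that ties a difference to a single change. The earlier compounds shown here, each differing from the others in more than one place, could not show that this position on the six-membered aromatic ring of carbon only responds to a substituent at all, or that the number moves downward when methoxy enters there. No measurement among the data offers a reason for this shift.

A hydroxyl group, an amine or a longer chain such as ethoxy at the same place would show whether the shift belongs to methoxy in particular or to any group that replaces the hydrogen. Going by these compounds, it also stays open whether the same change would move the number in the same direction on the core of compound 1 or of compound 2, since a single step supports no general rule.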